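The source may hold more compounds than are shown below. What is called first, only, known or untested is meant among the compounds shown, and "the series" means these compounds.

Measured so far:
compound 1 `O=C(O)c1ccccc1-c1ccc(CCc2ncc(C3CCCCC3)[nH]2)cc1`, 375 nM;
compound 2 `COc1cccc(Cc2cnc(CCc3ccc(-c4ccccc4C(=O)O)cc3)[nH]2)c1`, 4120 nM;
compound 3 `O=C(O)c1ccccc1-c1ccc(CCc2ncc(Cc3ccccc3Cl)[nH]2)cc1`, 292 nM.

In an in vitro functional assay on cells for agonist activity at Bombesin receptor subtype-3 (Homo sapiens), read by luminescence and calcium flux (a lower number here means that less compound is needed, a higher number that more compound is needed for the effect), compound 3 gives the lowest number of the three; compound 1 sits within the scatter of it, while compound 2 is far higher. Compound 4 `Cc1cccc(Cc2cnc(CCc3ccc(-c4ccccc4C(=O)O)cc3)[nH]2)c1` differs from compound 3 by 3-methylphenyl in place of 2-chlorophenyl on a saturated chain carbon bound to an aromatic carbon. For the measured compounds named here, the only step at this site is a 14-fold lower number from compound 2 to compound 3 (1.15 log units; beyond the scatter), which shows that exchanging a 2-chlorophenyl for a 3-substituted phenyl can move this assay a long way; the cyclohexyl steps an 11-fold higher number from compound 1 to compound 2 (1.04 log units; beyond the scatter) and a 1.3-fold lower number from compound 1 to compound 3 (0.11 log units; within the scatter) point the same way. Compound 4 is therefore expected to give a higher number than compound 3, a 5.1-fold higher number from compound 3 to compound 4 (0.71 log units; beyond the scatter), estimated at 1500 nM, between 400 nM and 5000 nM.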

Compound 4, half-maximal effective concentration: 4310 nM
The estimate for compound 4 lay 2.9-fold (0.46 log units) below the measured number, and the stated range covers the measured number.
By their numbers in this assay, from the lowest: compounds 3 and 1 (each within the scatter of the next); then compounds 2 and 4 (each within the scatter of the next).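

In this assay, the step of a 1.0-fold higher number from compound 2 to compound 4 (0.02 log units; within the scatter) lies within the scatter, so with methyl in place of methoxy on an aromatic carbon, the high number remains and does not depend on the methoxy group. The large steps of a 15-fold higher number from compound 3 to compound 4 (1.17 log units; beyond the scatter) and an 11-fold higher number from compound 1 to compound 4 (1.06 log units; beyond the scatter) set both compound 2 and compound 4, which carry 3-substituted benzyl groups, apart from compound 1 and compound 3. No measurement at hand explains the size of these steps. On these data alone, it remains open whether a 3-chlorobenzyl or a 2-methylbenzyl group would read like compound 3 or like compound 4.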